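Series notes: the N-substituent of compound 1

The source may hold more compounds than are shown below. What is called first, only, known or untested is meant among the compounds shown, and "the series" means these compounds.

Compound 1 `C=C(Br)C(=O)Nc1ccc(/C=C2\SC(=O)N(Cc3cccc(F)c3)C2=O)cc1` carries a bromoacrylamide on the aniline ring and a 3-fluorobenzyl group on the ring nitrogen of the shared core. In a functional assay on L1210 cells (Mus musculus) for cytotoxicity, read by cell counting, with a stated time of 2 days (on this read-out higher numbers stand for weaker inhibition and lower numbers for stronger inhibition), compound 1 gives 1200 nM, the second highest of the three numbers recorded. Compound 3 `C=C(Br)C(=O)Nc1cccc(/C=C2\SC(=O)N(Cc3ccccc3)C2=O)c1` gives 380 nM; it differs from compound 1 in two places, so only the two values are set side by side. Compound 2 `Nc1ccc(/C=C2\SC(=O)N(Cc3cccc(F)c3)C2=O)cc1`, which lacks the acrylamide, gives 100000 nM. Among the compounds with values here, the one single-place step known is the loss of that acrylamide, an 83-fold higher number from compound 1 to compound 2 (1.92 log units; beyond the scatter), which shows how much of the activity of compound 1 rests on that group.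

Compound 4 `C=C(Br)C(=O)Nc1ccc(/C=C2\SC(=O)N(CC)C2=O)cc1` keeps the acrylamide and changes only the benzylic substituent: methyl in place of 3-fluorophenyl on a saturated chain carbon bound to an amide-type nitrogen in a ring. Within the data shown here, no measured step touches this position, so the expectation rests on the retained acrylamide and on the spread of the two acrylamide-bearing compounds, compound 1 at 1200 nM and compound 3 at 380 nM. A modest step is expected, most likely towards a weaker number, a 1.7-fold higher number from compound 1 to compound 4 (0.22 log units; within the scatter). Compound 4 is therefore estimated at 2000 nM, with a range from 600 nM to 7000 nM.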

Compound 4, half-maximal inhibitory concentration: 500 nM
Compound 4: the middle estimate sits 4.0-fold (0.60 log units) above what was measured, outside the stated range (below it).
By their numbers in this assay, from the lowest: compounds 3 and 4 (each within the scatter of the next); then compound 1; then compound 2.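

With the acrylamide held in place, the change from 3-fluorobenzyl to ethyl gives a 2.4-fold lower number from compound 1 to compound 4 (0.38 log units; beyond the scatter) in this assay, so the 3-fluorophenyl group is not needed for the activity of compound 1. Within the data shown here, this is the first single-place reading at this position, on a saturated chain carbon bound to an amide-type nitrogen in a ring, and it shows that a methyl group here, with no aromatic ring, gives a number beyond the scatter on the stronger side of compound 1. No evidence is available to explain the direction or the size of this step.

The step removes the aromatic ring and the fluorine together, so the compounds shown cannot separate the share of each, and a plain benzyl group on the same aniline ring as compound 1 would be needed to do so. Also open, from the compounds shown here alone, is how far the trend holds at this position, whether with a longer chain such as butyl, or with a group such as an amine or a carboxylic acid on the chain.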